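Swapping the aryl amide of compound 1 for a cyclopropylmethyl

A few compounds are considered here, and "the series" means these few. Any claim that something is new, unique, unknown or untested is made for them only; others in the source may bear on it.

Measured compounds:
- compound 1, `CC(C)[C@@H](NC(=O)c1cccc(F)c1)C(=O)N1CCC(c2ccc(Cl)cc2)CC1`: 24 nM
- compound 2, `CC(C)C(NC(=O)c1ccc2ccccc2c1)C(=O)N1CCC(c2ccc(Cl)cc2)CC1`: 80 nM
- compound 3, `CC[C@@H](C)[C@@H](NC(=O)CCc1ccccc1)C(=O)N1CCC(c2ccc(Cl)cc2)CC1`: 66 nM

These three compounds were tested in an assay on THP-1 cells for displacement of a labelled ligand from C-C chemokine receptor type 1 (Homo sapiens); on this read-out higher numbers stand for weaker inhibition and lower numbers for stronger inhibition. Compound 1 gives the lowest of the three numbers, 24 nM. Compound 3 gives 66 nM, a gap that lies beyond the usual scatter of repeated measurements, and compound 2 gives 80 nM, also beyond the scatter. Compound 1 is therefore the most potent of the three in this assay.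

The next compound, compound 4, `CC(C)[C@@H](NC(=O)CC1CC1)C(=O)N1CCC(c2ccc(Cl)cc2)CC1`, has not yet been measured. It differs from compound 1 in one place: cyclopropylmethyl in place of 3-fluorophenyl on a carbonyl carbon. The shared core of the two compounds is otherwise unchanged.

Among the compounds with values here, no pair of the measured compounds differs in just one place, so nothing here shows directly what such an exchange on the carbonyl carbon does. Of the compounds that were measured, none carries a group like cyclopropylmethyl at that position, and both compounds 2 and 3 give higher numbers than compound 1. The expectation for compound 4 is a step of a 3.8-fold higher number from compound 1 to compound 4 (0.57 log units; beyond the scatter) in this assay, toward a higher number, beyond the scatter. The estimate for compound 4 in this assay is 90 nM, with a range from 30 nM to 300 nM.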

Compound 4, half-maximal inhibitory concentration: 46 nM
Compound 4: the middle estimate sits 2.0-fold (0.29 log units) above what was measured; the measured number falls inside the stated range.
By their numbers in this assay, from the lowest: compounds 1, 4, 3 and 2 (each within the scatter of the next, the first and the last beyond it).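

In this assay, putting cyclopropylmethyl in place of 3-fluorophenyl on a carbonyl carbon gives a 1.9-fold higher number from compound 1 to compound 4 (0.28 log units; within the scatter) and so this read-out cannot tell the two compounds apart. Within the data shown here, this is the first direct look at this position, and it shows that a six-membered aromatic ring is not required there to stay within the scatter of compound 1: a three-membered non-aromatic ring on a short carbon link, with 4 heavy atoms in place of 7, serves as well on this measure. No measured property of these groups is available to explain why the exchange is tolerated.

What the compounds shown leave open is how far this tolerance extends, since a single exchange marks only one point: a plain methyl, a longer chain such as n-butyl, an amine or a carboxylic acid on the same carbonyl carbon could each behave quite differently. From the compounds shown here alone, it also remains open whether the fluorine of compound 1 contributes anything, a question that an unsubstituted phenyl at this position would address.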